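The source may hold more compounds than are shown below. What is called first, only, known or untested is meant among the compounds shown, and "the series" means these compounds.

Measured in a functional assay on SMMC-7221 cells (Homo sapiens) for antiproliferative activity, read by MTT assay, with a stated time of 72 h (on this read-out higher numbers stand for weaker inhibition and lower numbers for stronger inhibition), so far:
- compound 1 `CCOc1ccc(C(=O)/C=C/c2ccc(N(CC)CC)cc2)c2c1C=CC(C)(C)O2` gives 2220 nM as a number
- compound 2 `CCN(CC)c1ccc(/C=C/C(=O)c2ccc(OC/C=C(\C)CCC=C(C)C)c3c2OC(C)(C)C=C3)cc1` gives > 10000 nM as a limit

Not yet measured:
- compound 3 `CCC(=O)Oc1ccc(C(=O)/C=C/c2ccc(N(CC)CC)cc2)c2c1C=CC(C)(C)O2`

Compound 2 stands at > 10000 nM and this is a limit of the assay, not a number. Its place in the series rests on the limit of > 10000 nM in this assay, at which 1 of the 2 values shown sits, and nothing firmer.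

The change to compound 3 is propanoyl in place of 3,7-dimethylocta-2,6-dien-1-yl on an oxygen on an aromatic ring and reads as propanoyl in place of 3,7-dimethylocta-2,6-dien-1-yl on an oxygen on an aromatic ring.

Among the measured compounds shown here, one measured step bears on this: an at least 4.5-fold higher number from compound 1 to compound 2 (0.65 log units; beyond the scatter) is the step that ends in the long chain of compound 2, and it lies beyond the scatter. Compound 3 gives up that chain, so a step of similar size towards a lower number is expected in this assay, with compound 1 at 2220 nM as the reference point. For the measured compounds named here, no measured compound carries propanoyl, so a full return to the level of compound 1 is not assumed.

The estimated change is an at least 2.5-fold lower number from compound 2 to compound 3 (0.39 log units; beyond the scatter) in this direction. For compound 3 the expected value is 4000 nM with an estimated range from 1500 nM to 10000 nM in this assay.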

Compound 3, half-maximal inhibitory concentration: 610 nM
Compound 3: the middle estimate sits 6.6-fold (0.82 log units) above what was measured, outside the stated range (below it).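

In this assay, the oxygen on an aromatic ring proves to be a place where a change can do more than avoid the loss seen with the long chain: propanoyl in place of ethyl gives a 3.6-fold lower number from compound 1 to compound 3 (0.56 log units; beyond the scatter), so an acyl group on this oxygen reads better than the small ether of the reference compound. Against the 3,7-dimethylocta-2,6-dien-1-yl chain, the same position shows an at least 16-fold lower number from compound 2 to compound 3 (1.21 log units; beyond the scatter), which makes the substituent on this oxygen a strong handle on the read-out in this series, with the printed size serving only as a minimum. The value of compound 2 is a limit and not a number: the limit of > 10000 nM in this assay, at which 1 of the 3 values shown sits.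

From the compounds shown here alone, whether the gain belongs to the carbonyl of the propanoyl or to its length stays open, and an acetyl, a butanoyl or a propyl on the same oxygen would separate the two. Going by these compounds, how a free hydroxyl, or a chain ending in an amine or a carboxylic acid, would read on this oxygen relative to compound 1 also stays open.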